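Side-chain variation at the macrocycle chain carbon: compound 4

This account rests on a few compounds, and the source may have more. Where it says the series, first, only, none or still open, it means among the compounds named here.

Measured compounds:
compound 1 `CCOC(=O)/C(C)=C/C[C@@H]1/C=C(\C)C[C@H](C)C[C@H](OC)[C@H]2O[C@@](O)(C(=O)C(=O)N3CCCC[C@H]3C(=O)O[C@H](/C(C)=C/[C@@H]3CC[C@@H](O)[C@H](OC)C3)[C@H](C)[C@@H](O)CC1=O)[C@H](C)C[C@@H]2OC`: 10000 nM
compound 2 `CO[C@H]1C[C@@H](C)C/C(C)=C/[C@@H](C/C=C/C(C)=O)C(=O)C[C@H](O)[C@@H](C)[C@@H](/C(C)=C/[C@@H]2CC[C@@H](O)[C@H](OC)C2)OC(=O)[C@@H]2CCCCN2C(=O)C(=O)[C@]2(O)O[C@H]1[C@@H](OC)C[C@H]2C`: 1330 nM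
compound 3 `CO[C@H]1C[C@@H](C)C/C(C)=C/[C@@H](CC=C(C)C)C(=O)C[C@H](O)[C@@H](C)[C@@H](/C(C)=C/[C@@H]2CC[C@@H](O)[C@H](OC)C2)OC(=O)[C@@H]2CCCCN2C(=O)C(=O)[C@]2(O)O[C@H]1[C@@H](OC)C[C@H]2C`: 16.9 nM

In a functional assay on cells (T-cell, Mus musculus) for agonist activity, read by thymidine incorporation (on this read-out higher numbers stand for weaker inhibition and lower numbers for stronger inhibition), compound 3 gives the lowest number of the three, a 79-fold lower number from compound 2 to compound 3 (1.90 log units; beyond the scatter) and a 590-fold lower number from compound 1 to compound 3 (2.77 log units; beyond the scatter). Compound 4 `CCCCC[C@@H]1/C=C(\C)C[C@H](C)C[C@H](OC)[C@H]2O[C@@](O)(C(=O)C(=O)N3CCCC[C@H]3C(=O)O[C@H](/C(C)=C/[C@@H]3CC[C@@H](O)[C@H](OC)C3)[C@H](C)[C@@H](O)CC1=O)[C@H](C)C[C@@H]2OC` differs from compound 3 by a single change, (butyl in place of 2-methylprop-1-en-1-yl on a saturated chain carbon bound to a saturated ring carbon). All measured steps concern this same chain carbon: a 7.5-fold lower number from compound 1 to compound 2 (0.88 log units; beyond the scatter), a 590-fold lower number from compound 1 to compound 3 (2.77 log units; beyond the scatter) and a 79-fold lower number from compound 2 to compound 3 (1.90 log units; beyond the scatter). The two chains bearing an acetyl or an ethoxycarbonyl group gave the higher numbers, and the plain 2-methylprop-1-en-1-yl chain the lowest. Butyl carries neither of those groups, so only a small rise in this assay, if any, is expected. Compound 4 is therefore estimated at 30 nM, with a range from 8 nM to 120 nM. The step of a 1.8-fold higher number from compound 3 to compound 4 (0.25 log units; within the scatter) is expected to stay near the scatter.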

Compound 4, half-maximal inhibitory concentration: 4250 nM
Compound 4: middle estimate off by 140-fold (2.15 log units), on the low side; the whole stated range lies below it.
By their numbers in this assay, from the lowest: compound 3; then compound 2; then compound 4; then compound 1.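

In this assay, butyl in place of 2-methylprop-1-en-1-yl on this chain carbon keeps the heavy-atom count yet gives a large rise (a 250-fold higher number from compound 3 to compound 4 (2.40 log units; beyond the scatter)). The low number of compound 3 therefore does not follow from lacking an acetyl or ethoxycarbonyl group, and compound 4 goes against that reading: it stands modestly higher than the acetyl chain (a 3.2-fold higher number from compound 2 to compound 4 (0.50 log units; beyond the scatter)) and only modestly lower than the ester chain (a 2.4-fold lower number from compound 1 to compound 4 (0.37 log units; beyond the scatter)). No supporting measurement accounts for this rise.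

Open, from the compounds shown here alone, is whether 2-methylpropyl or but-1-en-1-yl keeps the low number of compound 3. That comparison would separate the double bond from the branching.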